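Series notes: nitro in place of hydrogen on compound 1

The compounds below may be only part of what the source reports. "The series", "measured", "known", "first", "only" and "open" are said of these compounds alone.

Measured so far in a functional assay on PC-3 cells (Homo sapiens) for cytotoxicity, read by MTT assay, with a stated time of 48 h; a higher number here means a weaker inhibitor, a lower number a stronger inhibitor:

compound 1 `CCn1c(/C=C2/C(=O)Nc3ccccc32)nc2ccccc21` gives 38000 nM
compound 2 `CC(C)n1c(/C=C2/C(=O)Nc3ccccc32)nc2ccccc21` gives 37600 nM
compound 3 `CC(C)n1c(/C=C2/C(=O)Nc3ccc(Cl)cc32)nc2ccccc21` gives 38100 nM

In this assay compound 1 sits together with compound 2 and compound 3; the three numbers lie within the scatter of one another, so no order among them can be read. The step from compound 1 to compound 2 is a 1.0-fold lower number from compound 1 to compound 2 (0.00 log units; within the scatter), a methyl in place of hydrogen on the saturated chain carbon bound to the aromatic nitrogen. The step from compound 2 to compound 3 is a 1.0-fold higher number from compound 2 to compound 3 (0.01 log units; within the scatter), a chloro in place of hydrogen on an aromatic carbon.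

Compound 4 `CCn1c(/C=C2/C(=O)Nc3ccc([N+](=O)[O-])cc32)nc2ccccc21` is the next member. Relative to compound 1 the change is nitro in place of hydrogen on an aromatic carbon. The step that bears on it most directly is a 1.0-fold higher number from compound 2 to compound 3 (0.01 log units; within the scatter), where a different group entered at an aromatic carbon of the same ring without moving the number; a 1.0-fold lower number from compound 1 to compound 2 (0.00 log units; within the scatter) also shows the series flat under a change elsewhere. On this basis no step beyond the scatter is expected for compound 4, that is no change at the digits printed from compound 1 to compound 4 (within the scatter). Compound 4 is therefore estimated at 38000 nM in this assay, with an expected range from 15000 nM to 95000 nM.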

Compound 4, half-maximal inhibitory concentration: 40100 nM
For compound 4 the middle estimate is 1.1-fold (0.02 log units) below the measured one; the measured number falls inside the stated range.
By their numbers in this assay, from the lowest: compounds 2, 1, 3 and 4 (each within the scatter of the next).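

The step to the nitro group is a 1.1-fold higher number from compound 1 to compound 4 (0.02 log units; within the scatter) in this assay, so a group of 3 heavy atoms, with 2 hydrogen-bond acceptors and no net charge, on this aromatic carbon of the core of compound 1 gives a number within the scatter of the parent. Until now, substitution at this carbon had been read only as the chloro of compound 3, on the branched chain of compound 2; it can now also be read with the ethyl chain of compound 1, and neither step leaves the scatter. No measurement at hand accounts for this result.

Among the compounds shown, no step has yet left the scatter, so what this position tolerates is known only for chloro and nitro, and whether an amine or a carboxylic acid on this aromatic carbon would give a step beyond the scatter remains open. Also open, from the compounds shown here alone, are a longer chain on the aromatic nitrogen and the same nitro group on the other carbons of this six-membered aromatic ring.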